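Swapping an Ether Link for a Thioether Link

The source may hold more compounds than are shown below. What is called first, only, known or untested is meant among the compounds shown, and "the series" means these compounds.

Compound 1 `Nc1cc(N)c2nc(-c3ccccc3)c(Oc3ccc(Cl)c(Cl)c3)nc2c1` — 33900 nM
Compound 2 `CCOC(=O)[C@H](CCC(=O)O)NC(=O)c1ccc(CNc2nc3cc(N)cc(N)c3nc2-c2ccccc2)cc1` — < 100000 nM, a limit
Compound 3 `CCOC(=O)[C@H](CCC(=O)O)NC(=O)c1ccc(Oc2nc3cc(N)cc(N)c3nc2-c2ccccc2)cc1` — < 100000 nM, a limit

All three compounds were tested in a functional assay on Hs-578T cells (Homo sapiens) for inhibition, read by sulforhodamine B assay, with a stated time of 48 h; on this read-out lower numbers stand for stronger inhibition of growth and higher numbers for weaker inhibition of growth. Among the compounds with values here, compound 1 is the only one with an actual number: in this assay compound 1 gives 33900 nM. For compound 2 the assay returns only a limit, < 100000 nM. For compound 3 it likewise returns only a limit, < 100000 nM. Set against (the limit of < 100000 nM in this assay, at which 2 of the 3 values shown sit), compound 1 therefore stands alone as a measured point, and no step between two measured compounds can be drawn from these data.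

Compound 4 `Nc1cc(N)c2nc(-c3ccccc3)c(Sc3ccc(Cl)c(Cl)c3)nc2c1` differs from compound 1 in a single place: (3,4-dichlorophenyl)sulfanyl in place of 3,4-dichlorophenoxy on an aromatic carbon. Nothing measured here shows how such an exchange moves the read-out, so the expectation rests on compound 1 alone and on the small size of the change. The step of a 1.1-fold lower number from compound 1 to compound 4 (0.05 log units; within the scatter) is expected to lie within the usual scatter of this assay, in neither direction beyond it. The estimate for compound 4 is 30000 nM, with a range from 10000 nM to 90000 nM.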

Compound 4, concentration for total growth inhibition: < 100000 nM
Compound 4: no number, only a limit (the forecaster's own chance of this, stated with the estimate: 25%); the middle value does not contradict the limit.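

In this assay, within the data shown here, compound 4 returns only a limit of < 100000 nM and not a number, so no step from compound 1 to compound 4 can be read. It joins the other limits: the limit of < 100000 nM in this assay, at which 3 of the 4 values shown sit. On these data alone, whether (3,4-dichlorophenyl)sulfanyl in place of 3,4-dichlorophenoxy changes growth inhibition at all, and in which direction, stays open.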